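The compounds below may be only part of what the source reports. "The series", "measured", "known", "first", "only" and "open" are said of these compounds alone.

Compound 1 `COc1ccc(C(=O)/C=C/c2ccc(OCCNc3ccnc4cc(Cl)ccc34)c(OC)c2)c(OC)c1`: > 100 ug/mL
Compound 2 `COc1ccc(C(=O)/C=C/c2ccc(O)c(CN3CCN(c4ccnc5cc(Cl)ccc45)CC3)c2)c(OC)c1`: > 100 ug/mL
Compound 3 `COc1cc(/C=C/C(C)=O)ccc1OCc1cn(-c2ccnc3cc(Cl)ccc23)nn1`: 3.1 ug/mL

Of the compounds shown here, three have been tested in a physicochemical assay for solubility, at pH 2; a higher number here means a more soluble compound, a lower number a less soluble compound. For compound 1 the result is a limit of the assay, > 100 ug/mL, not a number. For compound 2 the result is likewise a limit, > 100 ug/mL. Within the data shown here, compound 3 is the only one with a measured number, 3.1 ug/mL, so it stands apart from the two others, which both sit at the limit of > 100 ug/mL in this assay, at which 2 of the 3 values shown sit.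

Compound 4 `COc1ccc(C(=O)/C=C/c2ccc(OCc3cn(-c4ccnc5cc(Cl)ccc45)nn3)c(OC)c2)c(OC)c1` has not yet been measured. It differs from compound 3 in one place: 2,4-dimethoxyphenyl in place of methyl on a carbonyl carbon. Put another way, the acetyl of compound 3 becomes a (2,4-dimethoxyphenyl)carbonyl. Among the measured compounds shown here, no measured pair shows this exact change, so its effect cannot be read from these data. The expectation is that compound 4 will be somewhat less soluble than compound 3, a step of a 2.6-fold lower number from compound 3 to compound 4 (0.41 log units; beyond the scatter) in this assay, though the step may also fall within the scatter. Compound 4 is therefore estimated at 1.2 ug/mL, between 0.3 ug/mL and 5 ug/mL.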

Compound 4, solubility: < 1.6 ug/mL
Compound 4: no number, only a limit (the forecaster's own chance of this, stated with the estimate: 20%); the middle value does not contradict the limit.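

In this assay compound 4 gives < 1.6 ug/mL, which is a limit of the assay and not a number. Placing 2,4-dimethoxyphenyl in place of methyl on a carbonyl carbon is the first change in one place that can be read in this series, and it gives an at least 1.9-fold lower number from compound 3 to compound 4 (0.28 log units; that floor lies within the scatter). The printed step is only a floor, so this single pair cannot settle whether the true change is small or large.

From the compounds shown here alone, it remains open how far the true value of compound 4 lies from its limit. Also open, going by these compounds, is how this carbonyl position would respond to other groups, such as a phenyl without the two methoxy groups, a chain carrying an amine, or a carboxylic acid.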